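The source may report more compounds than this note shows. Statements on the series, on what has been measured and on what is new or still open speak of the compounds shown alone.

Among the compounds with values here, in a functional assay on HepG2 cells (Homo sapiens) for antiproliferative activity, read by MTT assay, with a stated time of 72 h (on this read-out higher numbers stand for weaker inhibition and lower numbers for stronger inhibition), compound 1 `O=C(N/N=C/c1ccccc1)Nc1ccc(Oc2ccnc3[nH]ccc23)c(F)c1` gives 640 nM as the lower of the two numbers so far, and compound 2 `O=C(N/N=C/c1ccc([N+](=O)[O-])cc1)Nc1ccc(Oc2ccnc3[nH]ccc23)c(F)c1` gives 3030 nM as the higher. Compound 1 is therefore the stronger inhibitor of this pair. Compound 3 `O=C(N/N=C/c1ccccc1)Nc1ccc(Oc2ccnc3[nH]ccc23)cc1` has not been measured yet. It differs from compound 1 by hydrogen in place of fluoro on an aromatic carbon in a single place, with hydrogen in place of fluoro on an aromatic carbon. Within the data shown here, the one measured step is a 4.7-fold higher number from compound 1 to compound 2 (0.68 log units; beyond the scatter) and it is modest, but it comes from nitro in place of hydrogen elsewhere in the molecule, so it bears on this change only loosely. Among the measured compounds shown here, no measured pair tests the fluoro directly, so no change beyond the scatter is expected. The expected size is a 1.3-fold higher number from compound 1 to compound 3 (0.10 log units; within the scatter) in this estimate. Compound 3 is estimated at 800 nM with 340 nM to 1900 nM as its expected range.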

Compound 3, half-maximal inhibitory concentration: 750 nM
Estimate against measurement, compound 3: 1.1-fold (0.03 log units) above, within the range that was stated.
By their numbers in this assay, from the lowest: compounds 1 and 3 (each within the scatter of the next); then compound 2.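

In this assay hydrogen in place of fluoro gives a 1.2-fold higher number from compound 1 to compound 3 (0.07 log units; within the scatter) and so, at this place on the six-membered aromatic ring of carbon only, ortho to a large group and meta to a large group, the fluoro can be removed without a change that this read-out can distinguish. Within the data shown here, this is the first direct test of that atom, as the earlier step concerned a nitro group elsewhere in the molecule. Nothing measured here accounts for this result.

Only hydrogen and fluoro are shown at this place, so the effect of a chlorine atom, a methoxy group or an amine there remains an open question. Compound 2 also carries the fluoro but has no hydrogen partner, leaving open whether the same swap would behave alike with the nitro group present.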